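A few compounds are considered here, and "the series" means these few. Any claim that something is new, unique, unknown or untested is made for them only; others in the source may bear on it.

In a functional assay on MCF7 cells (Homo sapiens) for antiproliferative activity, read by MTT assay, with a stated time of 72 h (a higher number here means a weaker inhibitor, a lower number a stronger inhibitor), compound 1 `CC1=CC[C@H]2[C@H](CC[C@]2(C)O)C(C)(C)[C@@H]1CC[C@H]1[C@]2(C)CC[C@H](OC(=O)CCC(=O)O)C(C)(C)O[C@H]2CC[C@@]1(C)O` gives > 50000 nM, which is a limit of the assay and not a number. Among the compounds with values here, compound 2 `CC1=CC[C@H]2[C@H](CC[C@]2(C)O)C(C)(C)[C@@H]1CC[C@H]1[C@]2(C)CC[C@H](OC(=O)c3ccccc3C(F)(F)F)C(C)(C)O[C@H]2CC[C@@]1(C)O` gives 19200 nM, the only true number so far. Within the data shown here, the one measured step, an at least 2.6-fold lower number from compound 1 to compound 2 (0.41 log units; beyond the scatter), brought in 2-(trifluoromethyl)phenyl in place of 2-carboxyethyl on a carbonyl carbon. Compound 3 `CC1=CC[C@H]2[C@H](CC[C@]2(C)O)C(C)(C)[C@@H]1CC[C@H]1[C@]2(C)CC[C@H](OC(=O)c3ccco3)C(C)(C)O[C@H]2CC[C@@]1(C)O` has furan-2-yl in place of 2-(trifluoromethyl)phenyl on that carbonyl carbon: furan-2-yl in place of 2-(trifluoromethyl)phenyl on a carbonyl carbon. An aromatic ring stays there, so the measured step of an at least 2.6-fold lower number from compound 1 to compound 2 (0.41 log units; beyond the scatter) gives no reason to expect a full return to the limit of compound 1. A small move towards a higher number in this assay, possibly within the scatter, seems most likely. The expected result is a 1.3-fold higher number from compound 2 to compound 3 (0.11 log units; within the scatter). For compound 3 the estimated value is 25000 nM, with an expected range of 10000 nM to 50000 nM.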

Compound 3, half-maximal inhibitory concentration: 25700 nM
The estimate for compound 3 lay 1.0-fold (0.01 log units) below the measured number; the range from low to high includes it.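

In this assay, within the data shown here, furan-2-yl on the carbonyl carbon serves about as well as 2-(trifluoromethyl)phenyl, with a 1.3-fold higher number from compound 2 to compound 3 (0.13 log units; within the scatter): a five-membered aromatic ring with 1 hetero atom cannot be told apart here from a six-membered aromatic ring of carbon only that carries a trifluoromethyl group. Replacing 2-carboxyethyl with furan-2-yl gives an at least 1.9-fold lower number from compound 1 to compound 3 (0.28 log units; that floor lies within the scatter), and this floor alone does not separate the two compounds. Compound 1 gives > 50000 nM, which is a limit and not a number, so the true size of that step stays unknown: the limit of > 50000 nM in this assay, at which 1 of the 3 values shown sits.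

Going by these compounds, what a plain phenyl ring or a chain ending in an amine would do on that carbonyl carbon remains open. Also open, on these data alone, is whether any group there can bring the number well below that of compound 2, at 19200 nM.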